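Heptyl on the ring carbon of the brominated sulfonamide series

The compounds below may be only part of what the source reports. "The series", "measured", "known", "first", "only" and "open" are said of these compounds alone.

Compound 1, `Cc1ccc(S(=O)(=O)N2CCC(Cl)CC2)cc1`: in a functional assay on A2780 cells (Homo sapiens) for antiproliferative activity, read by sulforhodamine B assay, with a stated time of 48 h (a lower number here means a stronger inhibitor of growth, a higher number a weaker inhibitor of growth), compound 1 gives only a limit, > 100000 nM.
Compound 2, `Cc1ccc(S(=O)(=O)N2CC=C(Cl)CC2)cc1`: in this assay compound 2 gives only a limit, > 100000 nM.
Compound 3, `Cc1ccc(S(=O)(=O)N2CC=C(Br)CC2)cc1`: in this assay compound 3 gives only a limit, > 100000 nM.

Compound 3 thus stands at the limit of this assay, as do the other two, summed up as the limit of > 100000 nM in this assay, at which 3 of the 3 values shown sit. Among the measured compounds shown here, the one measured step, a step that the two limits leave unreadable from compound 2 to compound 3, is unreadable between two limits and gives no size. Compound 4, `CCCCCCCC1C=C(Br)CCN1S(=O)(=O)c1ccc(C)cc1`, differs from compound 3 by heptyl in place of hydrogen on a saturated ring carbon. For the measured compounds named here, no measured step bears on a heptyl, so no direction beyond the scatter is expected. The estimate for compound 4 is 80000 nM (range 10000 nM to 300000 nM), a step of an at least 1.2-fold lower number from compound 3 to compound 4 (0.09 log units; that floor lies within the scatter) expected mostly to end again at a limit.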

Compound 4, concentration for 50% growth inhibition: > 100000 nM
Compound 4 gave a limit, no number; the forecaster's own chance of this, stated with the estimate: 60%; middle value at least 1.2-fold (0.09 log units) from the limit.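

Compound 3 and compound 4 both give only a limit, so no step can be read between them: the limit of > 100000 nM in this assay, at which 4 of the 4 values shown sit.

The compounds shown leave open whether any change on the shared core gives a readable number in this assay.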